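The source may report more compounds than this note shows. Statements on the series, on what has been measured and on what is new or still open speak of the compounds shown alone.

Compound 1 `Cc1nc2c(c(-c3ccccc3)cn2-c2ccc(S(=O)(=O)Nc3nccs3)cc2)c(=O)[nH]1` and compound 2 `Cc1nc2c(c(-c3ccccc3)cn2-c2ccc(S(=O)(=O)Nc3ccccn3)cc2)c(=O)[nH]1` share one core. In a functional assay on HepG2 cells (Homo sapiens) for inhibition, read by sulforhodamine B assay, with a stated time of 24 h (on this read-out lower numbers stand for stronger inhibition and higher numbers for weaker inhibition), compound 1 gives 3390 nM, and compound 2 gives 3150 nM. The change between them, (pyridin-2-yl in place of 1,3-thiazol-2-yl on a sulfonamide nitrogen), made a 1.1-fold lower number from compound 1 to compound 2 (0.03 log units; within the scatter). Compound 3 `Nc1nc(=O)[nH]c2c1c(-c1ccccc1)cn2-c1ccc(S(=O)(=O)Nc2nccs2)cc1` carries a different core; the difference between the two cores is not broken down here. In this assay compound 3 gives 3490 nM. Within the data shown here, compound 4 `Nc1nc(=O)[nH]c2c1c(-c1ccccc1)cn2-c1ccc(S(=O)(=O)Nc2ccccn2)cc1` has not yet been measured in this assay; it differs from compound 3 by pyridin-2-yl in place of 1,3-thiazol-2-yl on a sulfonamide nitrogen, which is the same change as the one from compound 1 to compound 2, made at the same place. Because the earlier change gave a 1.1-fold lower number from compound 1 to compound 2 (0.03 log units; within the scatter), a step of similar size is expected for compound 4, a 1.1-fold lower number from compound 3 to compound 4 (0.04 log units; within the scatter). Compound 4 is therefore estimated at 3200 nM in this assay, most likely between 1600 nM and 6400 nM.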

Compound 4, half-maximal inhibitory concentration: 4300 nM
Estimate against measurement, compound 4: 1.3-fold (0.13 log units) below; the range from low to high includes it.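

In this assay, pyridin-2-yl in place of 1,3-thiazol-2-yl on a sulfonamide nitrogen gave a 1.2-fold higher number from compound 3 to compound 4 (0.09 log units; within the scatter). Set beside the earlier step, the change behaves alike on the two cores, leaving the number within the scatter on each: the same change on two cores in this assay, a 1.1-fold lower number (0.03 log units; within the scatter) from compound 1 to compound 2 and a 1.2-fold higher number (0.09 log units; within the scatter) from compound 3 to compound 4, 1.3-fold (0.12 log units) apart, within the scatter of two such steps. This shows that the swap is without a readable effect on either core, but it rests on a single pair per core, and it does not show that a change with a readable effect would carry over in the same way.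

The compounds shown leave open whether another group on the sulfonamide nitrogen, such as a methyl group or a chain ending in a carboxylic acid, would shift the number in this assay. They also leave open whether this swap would stay as small on any other core.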